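This account rests on a few compounds, and the source may have more. Where it says the series, first, only, none or still open, it means among the compounds named here.

In an ADME assay on BHK cells (Mesocricetus auratus) for cytotoxicity, read by MTT assay, with a stated time of 96 h (a higher number here means that more compound is tolerated, a lower number that less compound is tolerated), compound 2 `CC(=O)NC(=S)Nc1cccc(C(F)(F)F)c1` reads > 100000 nM, which is a limit of the assay and not a number. Compound 3 `FC(F)(F)c1cccc(NC(=S)Nc2cccc(Br)c2)c1` carries 3-bromophenyl in place of acetyl on an amide-type nitrogen. The closest guide is compound 1 `Fc1ccc(NC(=S)Nc2cccc(C(F)(F)F)c2)cc1`, which gives 26000 nM. Among the measured compounds shown here, the one measured step, an at least 3.8-fold higher number from compound 1 to compound 2 (0.58 log units; beyond the scatter), bears on this change, which runs the opposite way, from acetyl to an aromatic ring. A similar step towards a lower number is therefore expected in this assay, and the expected change is an at least 5.0-fold lower number from compound 2 to compound 3 (0.69 log units; beyond the scatter). For compound 3 the estimate is 20000 nM, with an expected range from 7000 nM to 60000 nM.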

Compound 3, half-maximal cytotoxic concentration: 10000 nM
Beside the measured number, compound 3's estimate is 2.0-fold (0.30 log units) above it; low and high end bracket the measured number.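

With 3-bromophenyl on this amide-type nitrogen, this assay shows an at least 10-fold lower number from compound 2 to compound 3 (1.00 log units; beyond the scatter), so the drop from acetyl seen with 4-fluorophenyl also appears with a second aromatic ring. The two rings are not interchangeable, as swapping 4-fluorophenyl for 3-bromophenyl gives a 2.6-fold lower number from compound 1 to compound 3 (0.41 log units; beyond the scatter). Compound 2 stands at a limit of the assay and not a number, so the step from acetyl gives only a minimum size: the limit of > 100000 nM in this assay, at which 1 of the 3 values shown sits. As far as these compounds go, whether the gap between the rings follows the halogen or its place on the ring stays open. So does where a longer chain or an amine on this nitrogen would fall.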